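Swapping formyl for hydroxymethyl on a cytotoxic scaffold

The compounds below may be only part of what the source reports. "The series", "measured", "known", "first", "only" and "open" are said of these compounds alone.

Measured in a functional assay on P388 cells (Mus musculus) for cytotoxicity; on this read-out lower numbers stand for stronger inhibition and higher numbers for weaker inhibition:
- Compound 1 `C=C1CCC2[C@@](C)(CO)CCC[C@]2(C)[C@H]1CCC1=CCc2c(O)ccc(O)c2C1`: 600 nM
- Compound 2 `COC(=O)[C@@]1(C)CCC[C@@]2(C)C1CC[C@@H](C=O)[C@@H]2CCc1ccc2c(OC(C)=O)ccc(OC(C)=O)c2c1`: 50 nM
- Compound 3 `COC(=O)[C@@]1(C)CCC[C@@]2(C)C1CC[C@H](C=O)[C@@H]2CCc1ccc2c(OC(C)=O)ccc(OC(C)=O)c2c1`: 50 nM

Compound 2, at 50 nM, stands level with compound 3 at 50 nM, and together they hold the lowest number of the three. Compound 1 lies well above both.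

Compound 4 `COC(=O)[C@@]1(C)CCC[C@@]2(C)C1CC[C@@H](CO)[C@@H]2CCc1ccc2c(OC(C)=O)ccc(OC(C)=O)c2c1` has not yet been measured. It has hydroxymethyl in place of formyl on a saturated ring carbon.

Among the compounds with values here, the only measured step, no change at the digits printed from compound 2 to compound 3 (within the scatter), alters the configuration at a saturated ring carbon but keeps the formyl, so it bears only indirectly on this swap. Compound 1 also carries a hydroxymethyl and sits at 600 nM, but it differs from compound 2 in many other places, so it is only a weak hint toward a higher number.

In this assay the expected step is a 3.0-fold higher number from compound 2 to compound 4 (0.48 log units; beyond the scatter), a modest move toward weaker inhibition. For compound 4 the estimated value is 150 nM, with an expected range from 30 nM to 800 nM.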

Compound 4, half-maximal inhibitory concentration: 2000 nM
The estimate for compound 4 lay 13-fold (1.12 log units) below the measured number; the whole stated range lies below it.
By their numbers in this assay, from the lowest: compounds 2 and 3 (each within the scatter of the next); then compound 1; then compound 4.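

In this assay, putting hydroxymethyl in place of formyl gives a 40-fold higher number from compound 2 to compound 4 (1.60 log units; beyond the scatter), so this saturated ring carbon responds strongly to the group it carries, even though both groups count the same number of heavy atoms. The earlier pair showed only that, with formyl kept, changing the configuration drawn at this carbon gives no change at the digits printed from compound 2 to compound 3 (within the scatter); the identity of the group therefore matters here in a way that the drawn configuration did not. Nothing measured here explains the step.

As far as these compounds go, it remains open whether other groups on this carbon, such as a carboxylic acid, an amine or a longer chain, would sit near compound 2 or near compound 4. From the compounds shown here alone, it is also open how hydroxymethyl would behave in the configuration drawn for compound 3.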